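A chloro added to the core of compound 1

The source may hold more compounds than are shown below. What is called first, only, known or untested is meant among the compounds shown, and "the series" means these compounds.

- Compound 1 `Clc1ccc(Cn2cnc3c(-c4ccco4)ncnc32)cc1Cl` gives > 10 ug/mL as a limit
- Compound 2 `Clc1cccc(Cn2cnc3c(-c4ccco4)ncnc32)c1` gives > 10 ug/mL as a limit

In a functional assay on Vero cells (Chlorocebus sabaeus) for inhibition (on this read-out lower numbers stand for stronger inhibition and higher numbers for weaker inhibition), compound 1 stands only at a limit, (the limit of > 10 ug/mL in this assay, at which 2 of the 2 values shown sit), so no number is known for it. Compound 3 `Clc1nc(-c2ccco2)c2ncn(Cc3ccc(Cl)c(Cl)c3)c2n1` carries chloro in place of hydrogen on an aromatic carbon on the shared core, between two ring nitrogen atoms. Within the data shown here, the only measured step, a step that the two limits leave unreadable from compound 1 to compound 2, concerns a different chloro and has no readable size. No step beyond the usual scatter is therefore expected, and no direction can be favoured. The expected change is a number no higher from compound 1 to compound 3 (the limit leaves the size open) in this assay. For compound 3 the estimated value is 10 ug/mL, with an expected range from 3 ug/mL to 30 ug/mL.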

Compound 3, half-maximal inhibitory concentration: > 10 ug/mL
Compound 3 was reported as a limit; the forecaster's own chance of this, stated with the estimate: 60%; the middle value lies on the limit itself.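

Compound 1 and compound 3 both stand only at a limit in this assay, so no step between them can be read: the limit of > 10 ug/mL in this assay, at which 3 of the 3 values shown sit.

The compounds shown leave open how strongly each one inhibits, and whether the added chloro changes that at all.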